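A few compounds are considered here, and "the series" means these few. Any claim that something is new, unique, unknown or untested is made for them only; others in the source may bear on it.

Working notes on the series.

Compound 1 `Nc1ncc(-c2ccc(C(=O)N3CCC(N)CC3)cc2)nc1-c1ccc(C(F)(F)F)cc1` is the reference point. Within the data shown here, in a physicochemical assay for solubility, read by HPLC, using the shake flask method, in phosphate buffer, with a stated time of 2 h, at pH 6.5 (a lower number here means a less soluble compound, a higher number a more soluble compound), compound 1 gives 88000 nM, which is the only numerical value in hand for the set. Compound 2 `N#Cc1ccc(-c2cnc(N)c(-c3ccc(N)nc3)n2)cc1` comes out in this assay at < 5000 nM, a limit of the assay and not a measured number. This is the case described in the limit of < 5000 nM in this assay, at which 1 of the 2 values shown sits. Among the measured compounds shown here, the two measured compounds differ in several places at once, so no single-change step is available, and the pair says only that compound 1 returns a number where compound 2 returns a limit.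

Compound 3 `Nc1ncc(-c2ccc(C(=O)N3CC[C@H](O)C3)cc2)nc1-c1ccc(C(F)(F)F)cc1` is the next compound to be run in this assay. Relative to compound 1 it differs in a single place: 3-hydroxypyrrolidin-1-yl in place of 4-aminopiperidin-1-yl on a carbonyl carbon. For the measured compounds named here, no measured step covers this kind of exchange, so the direction has to be an expectation. The working expectation is a step downward in solubility from compound 1 to compound 3 of a 2.9-fold lower number from compound 1 to compound 3 (0.47 log units; beyond the scatter), larger than the usual scatter. Compound 3 is accordingly estimated at 30000 nM, with a range from 8000 nM to 90000 nM.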

Compound 3, solubility: 68000 nM
Estimate against measurement, compound 3: 2.3-fold (0.36 log units) below; measured number inside the range.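

In this assay the series now has its first single-place step at the carbonyl carbon, a 1.3-fold lower number from compound 1 to compound 3 (0.11 log units; within the scatter), for 3-hydroxypyrrolidin-1-yl in place of 4-aminopiperidin-1-yl. The two compounds cannot be told apart in this read-out, and compound 3 returns a number just as compound 1 does, so within this pair the amino group of 4-aminopiperidin-1-yl is not needed for a measured value at this position, and the six-membered ring can give way to the five-membered ring without a step beyond the scatter. Nothing measured for these compounds accounts for this result, and the one limit in the set does not bear on this exchange.

Going by these compounds, it remains open whether the same holds for other groups on this carbonyl carbon, such as a carboxylic acid, a longer chain ending in an amine or the opposite stereoisomer of 3-hydroxypyrrolidin-1-yl. Compound 2 stands at < 5000 nM, which is a limit of the assay and not a number, and with several places changed at once, that limit cannot be assigned to any one of them.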